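Dimethoxy on the Benzoyl Arm of a Benzofuran Hydroxamate

This account rests on a few compounds, and the source may have more. Where it says the series, first, only, none or still open, it means among the compounds named here.

Measured compounds:
compound 1 `CC(=O)N(O)C(C)c1ccc2oc(-c3ccccc3)cc2c1`, 490 nM
compound 2 `COc1cc(-c2cc3cc(C(C)N(O)C(C)=O)ccc3o2)cc(OC)c1OC`, 310 nM
compound 3 `CC(c1ccc2oc(-c3ccccc3)cc2c1)N(O)C(=O)c1ccccc1`, 4830 nM

In an assay on RBL cells for inhibition of Polyunsaturated fatty acid 5-lipoxygenase (Rattus norvegicus) (a lower number here means a stronger inhibitor, a higher number a weaker inhibitor), compound 3 gives the highest of the three numbers. Within the data shown here, its nearest neighbour is compound 1, and the step of a 9.9-fold higher number from compound 1 to compound 3 (0.99 log units; beyond the scatter) is the only single-point change among the measured compounds; it shows that enlarging the group on the carbonyl carbon from methyl to phenyl raised the number well beyond the scatter. Compound 2 and compound 1 differ at the other end of the shared core, and their two values lie close together.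

Compound 4 `COc1ccc(C(=O)N(O)C(C)c2ccc3oc(-c4ccccc4)cc3c2)cc1OC` is not yet measured. It differs from compound 3 in one place: 3,4-dimethoxyphenyl in place of phenyl on a carbonyl carbon. Among the measured compounds shown here, no measured step touches the carbonyl aryl group itself, so nothing here speaks for a change in either direction. The values of compound 1 and compound 2 show that adding methoxy groups to an aryl ring elsewhere left the number roughly where it was, so little movement is expected for compound 4, a 1.2-fold lower number from compound 3 to compound 4 (0.08 log units; within the scatter). Compound 4 is therefore estimated at 4000 nM, within 1500 nM to 12000 nM.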

Compound 4, half-maximal inhibitory concentration: 200 nM
Estimate against measurement, compound 4: 20-fold (1.30 log units) above; the measured number lies below the stated range.
By their numbers in this assay, from the lowest: compounds 4, 2 and 1 (each within the scatter of the next, the first and the last beyond it); then compound 3.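

In this assay, the aryl group on the carbonyl carbon proves far from indifferent: a 24-fold lower number from compound 3 to compound 4 (1.38 log units; beyond the scatter) shows that what this ring carries can decide the result at this position. An aryl group here is therefore not in itself a loss, as the phenyl of compound 3 alone had suggested, for 3,4-dimethoxyphenyl also goes beyond methyl, with a 2.5-fold lower number from compound 1 to compound 4 (0.39 log units; beyond the scatter). Nothing measured here accounts for this reversal.

The compounds shown present the two methoxy groups only as a pair, so it remains open whether a single methoxy group would give the same result. Also open, on these data alone, is how an amine or a carboxylic acid on this ring would compare with 3,4-dimethoxyphenyl.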